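Amide Nitrogen Substituents on a Shared Core: Compound 4

The compounds below may be only part of what the source reports. "The series", "measured", "known", "first", "only" and "open" are said of these compounds alone.

Three compounds were measured in a functional assay on the whole organism for inhibition, with Rattus norvegicus as the target, read by cytopathic effect and paw edema, at a dose of 100 mg/kg by the oral route; on this read-out lower numbers stand for less inhibition and higher numbers for more inhibition at the one dose given (going by the name of the read-out):
compound 1, `CCCCNC(=O)c1c(O)c2cccnc2n(-c2ccccc2)c1=O`: 20.4%
compound 2, `O=C(NCc1ccccc1)c1c(O)c2cccnc2n(-c2ccccc2)c1=O`: 11.3%
compound 3, `O=C(NC1CCN(Cc2ccccc2)CC1)c1c(O)c2cccnc2n(-c2ccccc2)c1=O`: 1.2%

Compound 2 stands second highest of the three. Its nearest neighbour is compound 1, whose number is higher by an amount within the scatter, so no order between compound 1 and compound 2 can be claimed. Compound 3 gives the lowest number, and the gap from compound 2 down to compound 3 lies beyond the scatter.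

Compound 4, `O=C(Nc1ccc(Cl)cc1)c1c(O)c2cccnc2n(-c2ccccc2)c1=O`, has not yet been measured. It differs from compound 2 in one place: 4-chlorophenyl in place of benzyl on an amide-type nitrogen.

Within the data shown here, one measured step bears on the amide-type nitrogen: a number 9.1 percentage points lower from compound 1 to compound 2 (within the scatter), a change of the group on a saturated chain carbon bound to that nitrogen, which left the number within the scatter. Among the measured compounds shown here, no measured step puts an aromatic ring directly on the amide-type nitrogen, so the change from benzylamino to (4-chlorophenyl)amino has no direct precedent here. Compound 4 is therefore expected to give 15%, within 2% to 35%, meaning an expected step of a number 3.7 percentage points higher from compound 2 to compound 4 (within the scatter), with no clear direction beyond the scatter.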

Compound 4, a percentage reported as inhibition, in the whole organism at one dose (the size of the read-out at that dose, not a potency): 2.5%
Compound 4: middle estimate off by 12.5 percentage points, on the high side, within the range that was stated.
By their numbers in this assay, from the lowest: compounds 3, 4, 2 and 1 (each within the scatter of the next, the first and the last beyond it).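

In this assay, the step with 4-chlorophenyl in place of benzyl is a number 8.8 percentage points lower from compound 2 to compound 4 (within the scatter) and sets no order between the two compounds, so moving from a benzyl group to an aromatic ring directly on the amide-type nitrogen gives no readable change here. With butyl as the group replaced, the same position gives a number 17.9 percentage points lower from compound 1 to compound 4 (beyond the scatter) and so shows a step beyond the scatter, which the earlier step from butyl to benzyl did not. Nothing available here accounts for either step.

The compounds shown leave open whether the step from butyl goes with the aromatic ring or with its chlorine, a question that plain phenyl on the amide-type nitrogen would address. They also leave open how a longer chain such as hexyl, or a chain ending in a carboxylic acid, would read at this nitrogen.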